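The compounds below may be only part of what the source reports. "The series", "measured", "known", "first", "only" and "open" are said of these compounds alone.

Working notes on the shared core of compound 1 `Brc1cn2ccnc2c(-c2ccc3ncn(C4CCCCC4)c3c2)n1`, which in a functional assay on SK-MEL-5 cells (Homo sapiens) for inhibition, read by sulforhodamine B assay, with a stated time of 48 h, tested at 10 uM (on this read-out lower numbers stand for less inhibition and higher numbers for more inhibition at the one concentration tested (going by the name of the read-out)), gives 13.4%. For the measured compounds named here, compound 2 `COc1ccc(-c2cn3ccnc3c(-c3ccc4ncn(C5CCCCC5)c4c3)n2)cc1` carries 4-methoxyphenyl where compound 1 carries bromo, and in this assay compound 2 gives 92.3%, the highest of the three numbers so far, with compound 3 nearest and compound 1 furthest, both beyond the scatter. Compound 3 `Brc1ccc(-c2cn3ccnc3c(-c3ccc4ncn(C5CCCCC5)c4c3)n2)cc1` carries 4-bromophenyl and in this assay compound 3 gives 23.6%. The measured steps are a number 78.9 percentage points higher from compound 1 to compound 2 (beyond the scatter), a number 10.2 percentage points higher from compound 1 to compound 3 (beyond the scatter) and a number 68.7 percentage points lower from compound 2 to compound 3 (beyond the scatter): the group at this position moves the read-out over a wide span, and the two phenyl groups differ widely from each other.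

Compound 4 `c1csc(-c2cn3ccnc3c(-c3ccc4ncn(C5CCCCC5)c4c3)n2)c1` is not yet measured. Change: thiophen-2-yl in place of 4-methoxyphenyl on an aromatic carbon. Going by the values given here, no measured step makes this exact exchange. The nearest guidance is a number 68.7 percentage points lower from compound 2 to compound 3 (beyond the scatter), where bromo in place of methoxy removed most of the inhibition, and the modest a number 10.2 percentage points higher from compound 1 to compound 3 (beyond the scatter), where an aryl group without methoxy added little. A downward step in this assay is therefore expected for compound 4, likely large but uncertain in size. The expected step for compound 4 is a number 52.3 percentage points lower from compound 2 to compound 4 (beyond the scatter). For compound 4 in this assay a value of 40% is estimated, within 15% to 75%.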

Compound 4, a percentage reported as inhibition, at one concentration (the size of the read-out at that concentration, not a potency): 8.05%
Beside the measured number, compound 4's estimate is 32 percentage points above it; the whole stated range lies above it.
By their numbers in this assay, from the lowest: compounds 4 and 1 (each within the scatter of the next); then compound 3; then compound 2.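

In this assay, thiophen-2-yl in place of 4-methoxyphenyl gives a number 84.3 percentage points lower from compound 2 to compound 4 (beyond the scatter) and so shows that an aromatic ring at this position does not carry the inhibition by itself: among the three compounds with a ring here, only compound 2 stands high. The other two exchanges place the new group among the low numbers, with a number 15.6 percentage points lower from compound 3 to compound 4 (beyond the scatter) as a modest step and a number 5.4 percentage points lower from compound 1 to compound 4 (within the scatter) leaving thiophen-2-yl not separable from plain bromo, which sets the high number of compound 2 apart from all three other groups now seen at this position. Nothing on hand explains why 4-methoxyphenyl stands apart from the other groups here.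

Open, going by these compounds, is whether the methoxy group itself matters or only the whole 4-methoxyphenyl group, a question that an unsubstituted phenyl, a 4-hydroxyphenyl, a 4-ethoxyphenyl or a 4-aminophenyl at the same place would bear on. Also open, on these data alone, is how compound 2 behaves over a range of concentrations, since a single concentration gives the size of the read-out and not a potency.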